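This account rests on a few compounds, and the source may have more. Where it says the series, first, only, none or still open, it means among the compounds named here.

Measured compounds:
compound 1 `CNC1CCN(c2ccc3[nH]nc(-c4cnn(C)c4)c3c2)C1` — "not determined" (no result reported) in an assay on HEK293 cells for displacement of a labelled ligand from tyrosine-protein kinase receptor UFO (Homo sapiens), read by NanoBRET, with a stated time of 2 h; a higher number here means a weaker inhibitor, a lower number a stronger inhibitor
compound 2 `Cn1cc(-c2n[nH]c3ccc(N[C@H]4CCNC4)cc23)cn1` — > 50000 nM

Compound 1 has no result in this assay. For compound 2 the reported figure is only a limit of this assay, not a number: it reads > 50000 nM, so that compound 2 stands at the weak end of what this assay can resolve. The comparison of interest is with compound 3 `Cn1cc(-c2n[nH]c3ccc(N[C@@H]4CCNC4)cc23)cn1`, which has not been measured. It differs from compound 2 as follows: the two compounds have the same atoms and bonds and differ only in configuration as drawn: 1 of 1 stereo elements differ; a stereocentre at a saturated ring carbon is drawn S in compound 2 and R in compound 3. For the measured compounds named here, no measured pair of this kind is available here, so the size of the step in this assay cannot be drawn from the data. A change of configuration alone can leave potency unchanged or move it either way; the expectation is a step of an at least 1.6-fold lower number from compound 2 to compound 3 (0.22 log units; that floor lies within the scatter), most likely staying weak. Compound 3 is therefore estimated at 30000 nM, within a range from 2000 nM to 150000 nM.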

Compound 3, half-maximal inhibitory concentration: 20700 nM
For compound 3 the middle estimate is 1.4-fold (0.16 log units) above the measured one; the measured number falls inside the stated range.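

In this assay, the change of configuration at this saturated ring carbon from S to R gives an at least 2.4-fold lower number from compound 2 to compound 3 (0.38 log units; beyond the scatter), which compound 2 alone could not show. The step can be assigned to the stereocentre, because no atom or bond changes: the fact that compounds 2 and 3 differ only in the configuration as drawn Its true size remains unknown, because compound 2 carries a limit and not a number: the limit of > 50000 nM in this assay, at which 1 of the 3 values shown sits.

Even with the R configuration, compound 3 gives 20700 nM, and the compounds shown do not reveal whether the preference for R would persist if an acetyl group or a longer alkyl chain were added to the saturated ring. Compound 1 has no result, so they also leave open how its different attachment of the saturated ring to the shared core compares.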